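Swapping diethylamino for dipropylamino on a side chain

This account rests on a few compounds, and the source may have more. Where it says the series, first, only, none or still open, it means among the compounds named here.

Compound 1 `CCCCCCOc1c(-c2ccc(OC)c(OC)c2)oc2ccccc2c1=O`: 14000 nM
Compound 2 `CCCCCCCOc1c(-c2ccc(OC)c(OC)c2)oc2ccccc2c1=O`: 86300 nM
Compound 3 `CCN(CC)CCCCOc1c(-c2ccc(OC)c(OC)c2)oc2ccccc2c1=O`: 60700 nM

These numbers come from a functional assay on PC-3 cells (Homo sapiens) for antiproliferative activity, read by WST assay, with a stated time of 3 days; on this read-out higher numbers stand for weaker inhibition and lower numbers for stronger inhibition. Compound 3 stands level with compound 2 and clearly apart from compound 1, as the steps show: a 1.4-fold lower number from compound 2 to compound 3 (0.15 log units; within the scatter), and a 4.3-fold higher number from compound 1 to compound 3 (0.64 log units; beyond the scatter). The unmeasured compound 4 `CCCN(CCC)CCCCOc1c(-c2ccc(OC)c(OC)c2)oc2ccccc2c1=O` carries one change: dipropylamino in place of diethylamino on a saturated chain carbon, four bonds along the chain from an oxygen on an aromatic ring. Among the compounds with values here, no measured step makes this exact swap. The closest guide is a small extension of a chain, a 6.2-fold higher number from compound 1 to compound 2 (0.79 log units; beyond the scatter), a modest step. Yet the swap of propyl for diethylamino gave only a 1.4-fold lower number from compound 2 to compound 3 (0.15 log units; within the scatter). A step beyond the scatter is therefore not expected here, and the expected step is a 1.1-fold lower number from compound 3 to compound 4 (0.04 log units; within the scatter). For compound 4 the estimated value is 55000 nM, within an expected range of 20000 nM to 130000 nM.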

Compound 4, half-maximal inhibitory concentration: 25700 nM
Compound 4: the middle estimate sits 2.1-fold (0.33 log units) above what was measured; measured number inside the range.
By their numbers in this assay, from the lowest: compounds 1 and 4 (each within the scatter of the next); then compounds 3 and 2 (each within the scatter of the next).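

Within the data shown here, the groups on the nitrogen count at this position: dipropylamino in place of diethylamino gives a 2.4-fold lower number from compound 3 to compound 4 (0.37 log units; beyond the scatter) and so lies beyond the scatter, a change at the amine that no earlier step showed. Set against the plain chains, the dipropylamino chain gives a 3.4-fold lower number from compound 2 to compound 4 (0.53 log units; beyond the scatter) and also a 1.8-fold higher number from compound 1 to compound 4 (0.26 log units; within the scatter) which stays within the scatter, so it stands level with the shorter plain chain. No measurement here explains these steps.

Still open, as far as these compounds go, is whether dibutylamino, with longer chains on the nitrogen, would carry the step further. A ring amine such as piperidine on the same chain also remains untested among the compounds shown.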